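Swapping Methylsulfanyl for Carbamoyl at Two Different Places

The source may report more compounds than this note shows. Statements on the series, on what has been measured and on what is new or still open speak of the compounds shown alone.

Of the compounds shown here, three built on one shared core have been measured in a physicochemical assay for solubility, at pH 7.4; on this read-out lower numbers stand for lower solubility and higher numbers for higher solubility. Compound 1 `CSc1ccc(NC(=O)Nc2cc(C)nc3ccccc23)cc1` carries a methylsulfanyl group, and in this assay compound 1 gives 1300 nM. Compound 2 `CSc1ccccc1NC(=O)Nc1cc(C)nc2ccccc12` has the same atoms as compound 1, joined differently; the difference between the two cores is not broken down here. In this assay compound 2 gives 21000 nM, the highest of the three numbers. Compound 3 `Cc1cc(NC(=O)Nc2ccc(C(N)=O)cc2)c2ccccc2n1` replaces the methylsulfanyl of compound 1 by carbamoyl, a change described as carbamoyl in place of methylsulfanyl on an aromatic carbon, and in this assay compound 3 gives 900 nM. The resulting step of a 1.4-fold lower number from compound 1 to compound 3 (0.16 log units; within the scatter) is small.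

Compound 4 `Cc1cc(NC(=O)Nc2ccccc2C(N)=O)c2ccccc2n1` has not yet been measured. It arises from compound 2 by the change (carbamoyl in place of methylsulfanyl on an aromatic carbon). For the measured compounds named here, this is the same kind of change as the one from compound 1 to compound 3, but not the same: in compound 3 the carbamoyl stands para to a large group, whereas in compound 4 it stands ortho to a large group. Because the step of a 1.4-fold lower number from compound 1 to compound 3 (0.16 log units; within the scatter) stayed within the usual scatter, a similarly small step is expected here as well, namely a 1.8-fold lower number from compound 2 to compound 4 (0.24 log units; within the scatter), though the different surroundings of the place make this expectation less secure. Compound 4 is therefore estimated at 12000 nM, with an expected range from 3000 nM to 40000 nM.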

Compound 4, solubility: 200 nM
Compound 4: the middle estimate sits 60-fold (1.78 log units) above what was measured; measured number outside the range, below it.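

In this assay, the same swap of methylsulfanyl for carbamoyl produces two very different results: a 1.4-fold lower number from compound 1 to compound 3 (0.16 log units; within the scatter) is a step that stays within the usual scatter, while a 110-fold lower number from compound 2 to compound 4 (2.02 log units; beyond the scatter) is a large step well beyond it. This shows that, in this series, the size of the step seen on the core of compound 1 cannot simply be carried over to the core of compound 2, where the group sits on an aromatic carbon ortho to a large group; a change with the same name can therefore give a very different result on a closely related core, but this single pair of steps does not establish a general rule for other cores or other changes. Nothing shown here bears on why the two steps differ so much.

The compounds shown carry only methylsulfanyl or carbamoyl at the changing place, so it remains open whether a step of this size would also appear with an amine or a carboxylic acid there. Going by these compounds, with just these two pairs, it also remains open how such groups would compare between the core of compound 1 and the core of compound 2.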